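Swapping cyclobutyl for cyclopropyl on the shared core

The source may report more compounds than this note shows. Statements on the series, on what has been measured and on what is new or still open speak of the compounds shown alone.

In an ADME assay on microsomes from liver (Mus musculus) for metabolic stability, read by LC-MS, using NADPH, with a stated time of 10 min, tested at 10 uM (on this read-out higher numbers stand for a longer-lived compound and lower numbers for a shorter-lived compound), compound 1 `N#Cc1ccnc(Oc2nn(C3CCC3)c3ncnc(N)c23)c1` gives 0.4 h. Compound 3 `CC(C)(C)n1nc(Oc2cc(O)ccn2)c2c(N)ncnc21` gives 0.617 h, which lies within the usual scatter of compound 1. Compound 2 `Nc1ncnc2c1c(Oc1cc(Cl)ccn1)nn2C1CCC1` stands well apart at 0.0617 h. Among the compounds with values here, only one measured step changes a single place: a 6.5-fold lower number from compound 1 to compound 2 (0.81 log units; beyond the scatter), beyond the scatter, with chloro in place of cyano on an aromatic carbon. Compound 3 differs from compound 1 in more than one place, so it isolates no single change.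

Compound 4 `N#Cc1ccnc(Oc2nn(C3CC3)c3ncnc(N)c23)c1` has cyclopropyl in place of cyclobutyl on an aromatic nitrogen. Within the data shown here, no measured step touches that position, so the chloro step shows only that one change can matter, not what this change will do. No clear direction can be argued, and no shift beyond the scatter is expected. The estimated step is a 1.1-fold higher number from compound 1 to compound 4 (0.05 log units; within the scatter). The estimated half-life for compound 4 is 0.45 h, with an expected range from 0.18 h to 1.1 h.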

Compound 4, half-life: > 2.41 h
Compound 4 ended at the assay's limit; the forecaster's own chance of this, stated with the estimate: 5%; middle value at least 5.3-fold (0.72 log units) from the limit.
By their numbers in this assay, from the lowest: compound 2; then compounds 1 and 3 (each within the scatter of the next). At a limit, above all of these: compound 4.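

Cyclopropyl in place of cyclobutyl on an aromatic nitrogen gives an at least 6.0-fold higher number from compound 1 to compound 4 (0.77 log units; beyond the scatter) in this assay, the first step here that raises the number beyond the scatter, so the half-life responds to this position as well as to the swap of cyano for chloro. The two groups are a three-membered and a four-membered ring of carbon only, each with no hydrogen-bond donors, no hydrogen-bond acceptors and no net charge, so a change this small in the ring is enough to matter on this core. The value for compound 4 is a limit and not a number, and the step gives only a floor: the limit of > 2.41 h in this assay, at which 1 of the 4 values shown sits.

From the compounds shown here alone, it remains open whether cyclopropyl would give a similar step with chloro in place of cyano, as in compound 2. Going by these compounds, it also remains open how an open chain such as ethyl, or a ring holding oxygen such as oxetanyl, would behave on that nitrogen.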